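The source may report more compounds than this note shows. Statements on the series, on what has been measured and on what is new or still open speak of the compounds shown alone.

Measured compounds:
compound 1, `C=CC[C@@]12CCN[C@@H]1n1c3nc4ccc(OC)cc4cc3c(=O)c3cccc2c31`, gives 8900 nM in a functional assay on NCI-H460 cells (Homo sapiens) for inhibition, read by trypan blue exclusion, with a stated time of 72 h; a higher number here means a weaker inhibitor of growth, a lower number a stronger inhibitor of growth
compound 2, `COc1ccc2nc3c(cc2c1)c(=O)c1cccc2c1n3[C@H]1NCC[C@@]21CCO`, gives 850 nM in this assay
compound 3, `C=CC[C@@]12CCN(C(=O)OC(C)(C)C)[C@@H]1n1c3nc4ccc(O)c(CN(C)C)c4cc3c(=O)c3cccc2c31`, gives 17800 nM in this assay

One structural change can be followed twice in this set. Between compound 1 and compound 2 it reads (hydroxymethyl in place of vinyl on a saturated chain carbon bound to a saturated ring carbon). In this assay that change produced a 10-fold lower number from compound 1 to compound 2 (1.02 log units; beyond the scatter), a clear gain in growth inhibition.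

Compound 3 is built on a different core than compound 1; the difference between the two cores is not broken down here. What the numbers show is that compound 3 and compound 1 lie within the usual scatter of each other in this assay, while compound 2 stands well apart from both.

Compound 4, `CN(C)Cc1c(O)ccc2nc3c(cc12)c(=O)c1cccc2c1n3[C@H]1N(C(=O)OC(C)(C)C)CC[C@@]21CCO`, is compound 3 carrying the same change, (hydroxymethyl in place of vinyl on a saturated chain carbon bound to a saturated ring carbon), at the same kind of position. Because the earlier change gave a 10-fold lower number from compound 1 to compound 2 (1.02 log units; beyond the scatter), a step in the same direction is expected here, though a different core gives no guarantee that its size is carried over. The expected step from compound 3 is a 7.1-fold lower number from compound 3 to compound 4 (0.85 log units; beyond the scatter), taken somewhat more cautiously than the first.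

For compound 4 the expected value in this assay is 2500 nM, with a plausible span from 800 nM to 8000 nM.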

Compound 4, concentration for 50% growth inhibition: 16400 nM
Compound 4: the middle estimate sits 6.6-fold (0.82 log units) below what was measured; measured number outside the range, above it.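

On the core of compound 3, the swap of vinyl for hydroxymethyl (the same difference read as allyl to 2-hydroxyethyl) gives in this assay a 1.1-fold lower number from compound 3 to compound 4 (0.04 log units; within the scatter), so the clear gain in growth inhibition seen on the core of compound 1 does not appear on this second core. The size of this step therefore did not carry over from one core to the other, which is a warning against treating it as a fixed contribution of the change in this series: the same change on two cores in this assay, a 10-fold lower number (1.02 log units; beyond the scatter) from compound 1 to compound 2 and a 1.1-fold lower number (0.04 log units; within the scatter) from compound 3 to compound 4, 9.6-fold (0.98 log units) apart, beyond the scatter of two such steps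

This pair of steps does not show which feature of the two cores separates them, since the core of compound 3 differs from the core of compound 1 in more than one place, and two steps cannot reveal a general rule.

A core carrying only one of those differences would be needed to trace where the gain is lost. As far as these compounds go, it also remains open how growth inhibition on either core would respond to an amine or a carboxylic acid on this chain in place of the hydroxyl, or to a longer chain ending in a hydroxyl.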